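A few compounds are considered here, and "the series" means these few. Any claim that something is new, unique, unknown or untested is made for them only; others in the source may bear on it.

Working notes on the series in a functional assay on MCF7 cells (Homo sapiens) for antiproliferative activity, read by MTT assay, with a stated time of 24 h; on this read-out lower numbers stand for stronger inhibition and higher numbers for weaker inhibition: compound 1 `CCCC(O)(C#Cc1ccc(C(CC)(CC)C2=CN(CC)C(C(=O)NCCN(CC)CC)C2)cc1C)CCC` gives 1290 nM, compound 2 `CCN(CC)CCNC(=O)C1CC(C(CC)(CC)c2ccc(C#CC(O)C3CCC3)c(C)c2)=CN1CC` gives 1280 nM and compound 3 `CCN(CC)CCNC(=O)C1CC(C(CC)(CC)c2ccc(/C=C/C(O)(CC)CC)c(C)c2)=CN1CC` gives 690 nM, so compound 3 stands within the scatter of both others. Compound 4 `CCN(CC)CCNC(=O)C1CC(C(CC)(CC)c2ccc(CCC(O)(CC)CC)c(C)c2)=CN1CC` differs from compound 3 by a group of 8 heavy atoms (7 carbon, 1 oxygen; no ring) in place of a group of 8 heavy atoms (7 carbon, 1 oxygen; no ring), on an aromatic carbon: the 3-ethyl-3-hydroxypentyl group enters on an aromatic carbon, ortho to a methyl group and para to a large group. Two measured steps at this aromatic carbon bear on it, a 1.9-fold lower number from compound 1 to compound 3 (0.27 log units; within the scatter) and a 1.9-fold lower number from compound 2 to compound 3 (0.27 log units; within the scatter), and a 1.0-fold lower number from compound 1 to compound 2 (0.00 log units; within the scatter), on a triple-bonded carbon, adds a third. All three lie within the scatter. Among the measured compounds shown here, no measured compound carries the 3-ethyl-3-hydroxypentyl group, so the direction is open and no change beyond the scatter is expected. The expected step is a 1.2-fold higher number from compound 3 to compound 4 (0.09 log units; within the scatter). Compound 4 is estimated at 850 nM, with an expected range of 380 nM to 1900 nM.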

Compound 4, half-maximal inhibitory concentration: 3580 nM
Compound 4: the middle estimate sits 4.2-fold (0.62 log units) below what was measured; measured number above the stated range.
By their numbers in this assay, from the lowest: compounds 3, 2 and 1 (each within the scatter of the next); then compound 4.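

a 5.2-fold higher number from compound 3 to compound 4 (0.72 log units; beyond the scatter) and a 2.8-fold higher number from compound 2 to compound 4 (0.45 log units; beyond the scatter) as well as a 2.8-fold higher number from compound 1 to compound 4 (0.44 log units; beyond the scatter) make the 3-ethyl-3-hydroxypentyl group the first change at this aromatic carbon to pass the scatter. Compound 1, compound 2 and compound 3 lie within the scatter of each other, while compound 4, the only one with neither a double nor a triple bond in this group, stands apart from all three. Nothing measured here explains this result.

Going by these compounds, it remains open how an amine, a carboxylic acid or a longer saturated chain at this aromatic carbon would compare with the 3-ethyl-3-hydroxypentyl group. On these data alone, whether a saturated chain carrying a cyclobutyl ring would follow compound 4 is also open.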